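This account rests on a few compounds, and the source may have more. Where it says the series, first, only, none or still open, it means among the compounds named here.

Compound 1 `CN(C)c1ccc(N2C(=O)NC3(CSC4=C3C(=O)c3ncccc3C4=O)C2=O)cc1` belongs to a small set of three compounds that share one core and differ only in the group carried on the aromatic ring attached to a ring nitrogen. In a functional assay on SF-268 cells (Homo sapiens) for antiproliferative activity, read by MTT assay, with a stated time of 96 h (a higher number here means a weaker inhibitor, a lower number a stronger inhibitor), compound 1 gives 950 nM, the highest of the three numbers. Compound 2 `CCCc1ccc(N2C(=O)NC3(CSC4=C3C(=O)c3ncccc3C4=O)C2=O)cc1` gives 300 nM in this assay, and compound 3 `COc1ccc(N2C(=O)NC3(CSC4=C3C(=O)c3ncccc3C4=O)C2=O)cc1` gives 650 nM. The measured steps are a 3.2-fold lower number from compound 1 to compound 2 (0.50 log units; beyond the scatter), a 1.5-fold lower number from compound 1 to compound 3 (0.16 log units; within the scatter) and a 2.2-fold higher number from compound 2 to compound 3 (0.34 log units; beyond the scatter); each swaps one group for another on the aromatic carbon while the ring itself stays in place. Compound 4 `O=C1NC(=O)C2(CSC3=C2C(=O)c2ncccc2C3=O)N1` differs from compound 1 in a more drastic way: hydrogen in place of 4-(dimethylamino)phenyl on an amide-type nitrogen in a ring. Within the data shown here, none of the measured steps removes that ring, so none bears directly on this change; they only show that altering the group on the ring moved the number by modest amounts. Taking away the whole group is a larger change than any of those, and its direction has no measured guide here. Compound 4 is therefore expected to give 3000 nM, within a wide range from 600 nM to 15000 nM. That estimate corresponds to an expected step of a 3.2-fold higher number from compound 1 to compound 4 (0.50 log units; beyond the scatter).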

Compound 4, half-maximal inhibitory concentration: 3100 nM
For compound 4 the middle estimate is 1.0-fold (0.01 log units) below the measured one; low and high end bracket the measured number.
By their numbers in this assay, from the lowest: compound 2; then compounds 3 and 1 (each within the scatter of the next); then compound 4.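

With hydrogen on the amide-type nitrogen in place of the whole aromatic group, the number in this assay goes up in all three comparisons (a 3.3-fold higher number from compound 1 to compound 4 (0.51 log units; beyond the scatter); a 4.8-fold higher number from compound 3 to compound 4 (0.68 log units; beyond the scatter); a 10-fold higher number from compound 2 to compound 4 (1.01 log units; beyond the scatter)). So the shared core still gives a measurable number with nothing but hydrogen at this position, yet each of the three compounds with an aromatic group here gives a lower number, and the step is largest when 4-propylphenyl leaves. No measurement given here explains what the aromatic group contributes at this position.

From the compounds shown here alone, it remains open whether a smaller group on this nitrogen, such as methyl or an unsubstituted phenyl ring, would keep the lower numbers. Going by these compounds, it is also open how a chain longer than propyl, an amine or a carboxylic acid on the aromatic ring would compare.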